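The compounds below may be only part of what the source reports. "The series", "measured", "known", "first", "only" and "open" are said of these compounds alone.

Compound 1 `C/C(=C\Cc1ccc(=O)c(O)cc1C(C)C)CO` and compound 2 `C/C(=C\C[C@]12C=C[C@@]1(O)C(=O)C=C2C(C)C)CO` were tested in a functional assay on HepG2 cells (Homo sapiens) for inhibition, with a stated time of 24 h, tested at 20 uM; a higher number here means more inhibition at the concentration tested (going by the name of the read-out), a lower number less inhibition. Compound 1 gives 29%, and compound 2 gives 29%, so compound 2 stands level with compound 1 at the digits shown, within the usual scatter. Compound 3 `C/C(=C\C[C@@]12C=C[C@]1(O)C(=O)C=C2C(C)C)CO` has not been measured. It differs from compound 2 only in configuration: the two compounds have the same atoms and bonds and differ only in configuration as drawn: 2 of 3 stereo elements differ; a stereocentre at a saturated ring carbon is drawn R in compound 2 and S in compound 3; a stereocentre at a saturated ring carbon is drawn S in compound 2 and R in compound 3. For the measured compounds named here, no step between measured compounds is available, so the expectation rests on compound 2 alone. The step of no change at the digits printed from compound 2 to compound 3 (within the scatter) is expected to be small, in no firm direction, and within the scatter. Compound 3 is therefore estimated at 29%, with a range from 12% to 46%.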

Compound 3, a percentage reported as inhibition, at one concentration (the size of the read-out at that concentration, not a potency): 29%
Compound 3: middle estimate and measured number agree at the digits printed; the measured number falls inside the stated range.
By their numbers in this assay, from the lowest: compounds 1, 2 and 3 (each within the scatter of the next).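

In this assay, swapping the drawn configuration at the two saturated ring carbons gives no change at the digits printed from compound 2 to compound 3 (within the scatter). For the compounds shown here, this is the first comparison here that isolates configuration, and for this pair, at the one concentration tested, the read-out does not separate the two forms. The comparison concerns a single feature: the fact that compounds 2 and 3 differ only in the configuration as drawn

The compounds shown leave open whether the same holds at other concentrations or exposure times. They also leave open whether a carboxylic acid or an amine in place of the hydroxyl group on the side chain would shift this read-out.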